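Cyclohexyl gives way to 3-bromophenyl

The compounds below may be only part of what the source reports. "The series", "measured", "known", "first", "only" and "open" are said of these compounds alone.

compound 1 `Cc1cc(Nc2cc(-c3ccccc3)[nH]n2)n2nc(SCCc3ccccc3)nc2n1`: 37400 nM
compound 2 `Cc1cc(Nc2cc(-c3cccs3)[nH]n2)n2nc(SCc3ccc(Br)cc3)nc2n1`: 38700 nM
compound 3 `Cc1cc(Nc2cc(-c3ccccc3)[nH]n2)n2nc(SCC3CCCCC3)nc2n1`: > 50000 nM

All three compounds were tested in an ADME assay on GES1 cells (Homo sapiens) for inhibition, read by MTT assay, with a stated time of 72 h; a higher number here means a weaker inhibitor, a lower number a stronger inhibitor. Compound 3 reads > 50000 nM there, which is a limit of the assay and not a number.

The next compound is compound 4 `Cc1cc(Nc2cc(-c3ccccc3)[nH]n2)n2nc(SCc3cccc(Br)c3)nc2n1`. It has 3-bromophenyl in place of cyclohexyl on a saturated chain carbon bound to a sulfur.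

For the measured compounds named here, only one measured step bears on this change: an at least 1.3-fold higher number from compound 1 to compound 3 (0.12 log units; that floor lies within the scatter). That step put cyclohexyl in where an aromatic ring had been, while the new change goes the other way, so it points to a lower number, though its size is known only as a floor. Compound 2 also carries a bromine-bearing ring on its sulfur chain, but it differs elsewhere too, and it gives 38700 nM. Compound 1 gives 37400 nM.

A small step toward these two values therefore seems likely in this assay. The estimated change is an at least 1.3-fold lower number from compound 3 to compound 4 (0.14 log units; that floor lies within the scatter). For compound 4 the expected value is 36000 nM, with an estimated range of 17000 nM to 60000 nM.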

Compound 4, half-maximal inhibitory concentration: > 50000 nM
Compound 4 gave a limit, no number (the forecaster's own chance of this, stated with the estimate: 25%); at least 1.3-fold (0.14 log units) between middle value and limit.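

In this assay compound 4 ends at a limit of the assay and not at a number, as compound 3 does, so the step between them cannot be read: the limit of > 50000 nM in this assay, at which 2 of the 4 values shown sit.

For the compounds shown here, a 3-bromophenyl ring on this saturated chain carbon bound to a sulfur thus leaves the reading at the limit just as cyclohexyl does, which the earlier compounds could not show. Going by these compounds alone, the one readable step is an at least 1.3-fold higher number from compound 1 to compound 4 (0.12 log units; that floor lies within the scatter), so this result does not separate compound 4 from compound 1 beyond the usual scatter.

Going by these compounds, how far compound 3 and compound 4 actually lie past the limit stays unknown. Also open, on these data alone, is what an amine or a carboxylic acid on this ring would read in this assay.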